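A Methyl Added to the Central Ring of a Benzyloxy Isoxazole

The source may hold more compounds than are shown below. What is called first, only, known or untested is meant among the compounds shown, and "the series" means these compounds.

Three compounds sharing one core were compared in a functional assay on Huh-7 cells (Homo sapiens) for antiproliferative activity, read by sulforhodamine B assay, with a stated time of 72 h; a lower number here means a stronger inhibitor, a higher number a weaker inhibitor. Compound 1 `Cc1cccc(COc2ccc(-c3cc(CN4CCN(Cc5ccc(C(F)(F)F)cc5)CC4)no3)cc2)c1` gives 5000 nM in this assay. Compound 2 `Cc1cc(C)cc(COc2ccc(-c3cc(CN4CCN(Cc5ccc(C(F)(F)F)cc5)CC4)no3)cc2)c1` gives 600 nM, and compound 3 `N#Cc1cccc(COc2ccc(-c3cc(CN4CCN(Cc5ccc(C(F)(F)F)cc5)CC4)no3)cc2)c1` gives 100 nM. The change from compound 1 to compound 2, (methyl in place of hydrogen on an aromatic carbon), produced an 8.3-fold lower number from compound 1 to compound 2 (0.92 log units; beyond the scatter). The change from compound 1 to compound 3, (cyano in place of methyl on an aromatic carbon), produced a 50-fold lower number from compound 1 to compound 3 (1.70 log units; beyond the scatter), and between the two substituted benzyl ethers the step was a 6.0-fold lower number from compound 2 to compound 3 (0.78 log units; beyond the scatter). Compound 3 therefore stands lowest of the three, with both of its steps to the others beyond the scatter.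

Compound 4 `Cc1cc(OCc2cccc(C#N)c2)ccc1-c1cc(CN2CCN(Cc3ccc(C(F)(F)F)cc3)CC2)no1` has not been measured. It differs from compound 3 by methyl in place of hydrogen on an aromatic carbon. This is the same kind of change that was made from compound 1 to compound 2, but not the same: in compound 2 the methyl sits meta to a large group and meta to a methyl group, whereas in compound 4 it sits ortho to a large group and meta to a (3-cyanobenzyl)oxy group, on a different six-membered aromatic ring of carbon only. The cores of compound 1 and compound 3 differ by cyano in place of methyl on an aromatic carbon.

Because the earlier methyl addition gave an 8.3-fold lower number from compound 1 to compound 2 (0.92 log units; beyond the scatter) on a different ring, only a weak transfer is expected here; the step from compound 3 to compound 4 is estimated at a 1.4-fold lower number from compound 3 to compound 4 (0.15 log units; within the scatter). Compound 4 is expected to give about 70 nM, within 20 nM to 250 nM.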

Compound 4, half-maximal inhibitory concentration: 1500 nM
Estimate against measurement, compound 4: 21-fold (1.33 log units) below; the measured number lies above the stated range.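

In this assay, methyl in place of hydrogen, ortho to a large group and meta to a (3-cyanobenzyl)oxy group, gave a 15-fold higher number from compound 3 to compound 4 (1.18 log units; beyond the scatter), so this addition ran the opposite way to the earlier one on the other ring. Set side by side, the two methyl additions share a name but not an outcome, and the result of the first did not carry over to the second: the same change on two cores in this assay, an 8.3-fold lower number (0.92 log units; beyond the scatter) from compound 1 to compound 2 and a 15-fold higher number (1.18 log units; beyond the scatter) from compound 3 to compound 4, 130-fold (2.10 log units) apart, beyond the scatter of two such steps This shows that, within these compounds, the direction of a methyl addition on an aromatic carbon cannot be taken from one core to another, but it does not show why, since the two steps differ both in the ring that carries the methyl and in the rest of the core, and one pair on each ring cannot separate these.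

The compounds shown leave open whether the rise in compound 4 belongs to methyl itself or would also follow a smaller atom such as fluorine, or a methoxy group, on the same carbon. They also leave open whether the same ring methyl would give a similar step on the core of compound 1, which carries a methyl in place of the nitrile.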